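This account rests on a few compounds, and the source may have more. Where it says the series, first, only, none or still open, it means among the compounds named here.

So far, three compounds sharing one core have been tested in a functional assay on MCF7 cells (Homo sapiens) for antiproliferative activity, read by MTT assay, with a stated time of 72 h (a higher number here means a weaker inhibitor, a lower number a stronger inhibitor), and a fourth awaits its result. Compound 1 (`CC/C=C/C(=O)Nc1cccc(Oc2nc(Nc3ccn(C)n3)nc3c2CSCC3)c1`) gives > 50000 nM and this is a limit of the assay, not a number. Compound 2 (`CC/C=C/C(=O)Nc1cccc(Oc2nc(Nc3cccc(C#N)c3)nc3c2CSCC3)c1`) gives 15900 nM and compound 3 (`C=CC(=O)Nc1cccc(Oc2nc(Nc3ccc(OC)cc3)nc3c2CSCC3)c1`) gives 11700 nM and so stands within the scatter of compound 2. Compound 4 (`CC/C=C/C(=O)Nc1cccc(Oc2nc(Nc3ccc(OC)cc3)nc3c2CSCC3)c1`) differs from compound 3 in one place: but-1-en-1-yl in place of vinyl on a carbonyl carbon and so but-1-en-1-yl replaces vinyl on a carbonyl carbon. For the measured compounds named here, the only measured step is an at least 3.1-fold lower number from compound 1 to compound 2 (0.49 log units; beyond the scatter) and it changes the group on a nitrogen on an aromatic ring, not this one, so it gives no direct measure of the new change. The closest guide is that compound 4 shares its but-1-en-1-yl group with compound 2 at 15900 nM in a compound that also differs elsewhere. In this assay the expected result is a 1.4-fold higher number from compound 3 to compound 4 (0.14 log units; within the scatter) and so a small rise at most, not a clear move. Compound 4 is estimated at 16000 nM with an expected range from 7000 nM to 45000 nM as the likely span.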

Compound 4, half-maximal inhibitory concentration: 31400 nM
The estimate for compound 4 lay 2.0-fold (0.29 log units) below the measured number, within the range that was stated.
By their numbers in this assay, from the lowest: compounds 3, 2 and 4 (each within the scatter of the next, the first and the last beyond it). At a limit, above all of these: compound 1.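

In this assay, the change on the carbonyl carbon now has a direct measure: but-1-en-1-yl in place of vinyl gives a 2.7-fold higher number from compound 3 to compound 4 (0.43 log units; beyond the scatter) with 4-methoxyphenyl held on the nitrogen, so here the longer group gives a weaker compound. With but-1-en-1-yl held fixed, 4-methoxyphenyl in place of 3-cyanophenyl gives a 2.0-fold higher number from compound 2 to compound 4 (0.30 log units; within the scatter) and so shows no clear effect of that change on the nitrogen. Also with but-1-en-1-yl held fixed, 4-methoxyphenyl in place of 1-methyl-1H-pyrazol-3-yl gives an at least 1.5-fold lower number from compound 1 to compound 4 (0.20 log units; that floor lies within the scatter). The size of this step cannot be read, because it rests on a limit and not a number: the limit of > 50000 nM in this assay, at which 1 of the 4 values shown sits.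

As far as these compounds go, whether the change from vinyl to but-1-en-1-yl has the same effect with 3-cyanophenyl or 1-methyl-1H-pyrazol-3-yl on the nitrogen stays open. So does how a longer chain ending in an amine on the carbonyl carbon would compare with vinyl.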